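The compounds below may be only part of what the source reports. "The series", "measured", "known", "first", "only" and "open" are said of these compounds alone.

- compound 1 `CCC(NC(=O)c1ccc(C(=N)N)cc1)C(C)(C)C(=O)N1CCC(CC(=O)O)CC1`: 1.3 h
- compound 2 `CC(C)CC(NC(=O)c1ccc(C(=N)N)cc1)C(C)(C)C(=O)N1CCC(CC(=O)O)CC1`: 0.917 h

In an in vivo ADME assay on the whole organism (Cavia porcellus) (a higher number here means that the compound lasts longer, a lower number that the compound disappears faster), compound 2 gives 0.917 h, and compound 1 gives 1.3 h. These two values lie within the scatter of each other, so compound 2 cannot be set apart from compound 1 on these numbers.

Compound 3 `CCCCCC(NC(=O)c1ccc(C(=N)N)cc1)C(C)(C)C(=O)N1CCC(CC(=O)O)CC1` is the next case. Its change from compound 2 is butyl in place of isopropyl on a saturated chain carbon, two bonds along the chain from an amide-type nitrogen.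

Among the compounds with values here, only one measured step bears on this, the change at the same place from methyl to isopropyl, a 1.4-fold lower number from compound 1 to compound 2 (0.15 log units; within the scatter). That step stayed within the scatter, but it is a single step and a different swap. No step beyond the scatter is therefore expected in this assay, and the estimated step is a 1.1-fold lower number from compound 2 to compound 3 (0.03 log units; within the scatter). For compound 3 the estimated half-life is 0.85 h, with an expected range from 0.45 h to 1.6 h.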

Compound 3, half-life: 0.517 h
Estimate against measurement, compound 3: 1.6-fold (0.22 log units) above; measured number inside the range.
By their numbers in this assay, from the lowest: compounds 3, 2 and 1 (each within the scatter of the next, the first and the last beyond it).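

In this assay the swap of butyl for isopropyl on a saturated chain carbon, two bonds along the chain from an amide-type nitrogen, gives a 1.8-fold lower number from compound 2 to compound 3 (0.25 log units; within the scatter) and so does not by itself set compound 3 apart from compound 2. Taken from the smallest group at this place, however, propyl in place of hydrogen, three bonds along the chain from an amide-type nitrogen, gives a 2.5-fold lower number from compound 1 to compound 3 (0.40 log units; beyond the scatter) and is the first step at this position to pass beyond the scatter, though only modestly. Nothing available explains this difference.

The compounds shown leave open whether a longer chain at this place would shorten the half-life further. They also leave open how a hydroxyl group or an amine on the chain would compare with these purely carbon groups.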